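A few compounds are considered here, and "the series" means these few. Any claim that something is new, unique, unknown or untested is made for them only; others in the source may bear on it.

Working notes on the series. In an assay on MCF7 cells for inhibition of Serine-protein kinase ATM (Homo sapiens), read by immunofluorescence, with a stated time of 1 h (on this read-out lower numbers stand for stronger inhibition and higher numbers for weaker inhibition), compound 1 `Nc1cc2c(-n3nc(-c4ccccn4)nc3N)ncnc2cc1Cl` gives > 40000 nM, a limit of the assay rather than a number. Compound 1 thus sits at the limit of > 40000 nM in this assay, at which 1 of the 3 values shown sits. In this assay compound 2 `COc1cc2ncnc(-n3nc(-c4ccncc4)nc3N)c2cc1OC` gives 5000 nM. In this assay compound 3 `COc1cc2ncnc(-n3nc(-c4ccccn4)cc3N)c2cc1OC` gives 1600 nM, the lowest of the two numbers; compound 2 lies beyond the scatter from it. Compound 4 `COc1cc2ncnc(-n3nc(-c4ccc(C)cc4)cc3N)c2cc1OC` differs from compound 3 by 4-methylphenyl in place of pyridin-2-yl on an aromatic carbon. For the measured compounds named here, no measured pair of this kind exists in the set, so the size of the step is open; a small move toward weaker inhibition is expected, as the step from compound 3 to compound 4 is estimated at a 1.9-fold higher number from compound 3 to compound 4 (0.27 log units; within the scatter). For compound 4 the expected value in this assay is 3000 nM, within 800 nM to 12000 nM.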

Compound 4, half-maximal inhibitory concentration: > 40000 nM
Compound 4 was reported as a limit; the forecaster's own chance of this, stated with the estimate: 5%; middle value at least 13-fold (1.12 log units) away from the limit.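

For the compounds shown here, at this position, on the aromatic carbon next to the ring nitrogen, the change from pyridin-2-yl to 4-methylphenyl gives an at least 25-fold higher number from compound 3 to compound 4 (1.39 log units; beyond the scatter) in this assay, the only single-place step. Inhibition here therefore depends strongly on the aromatic group carried at this carbon. The value of compound 4 is a limit of the assay and not a number, so the step has no measured upper end: the limit of > 40000 nM in this assay, at which 2 of the 4 values shown sit.

The compounds shown leave open whether the loss of the ring nitrogen or the added methyl accounts for the step. Unsubstituted phenyl or a methyl-bearing pyridin-2-yl at this carbon would separate the two.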